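This account rests on a few compounds, and the source may have more. Where it says the series, first, only, none or still open, it means among the compounds named here.

Measured so far, in an assay on isolated protein for inhibition of histone deacetylase 8 (Homo sapiens), read by fluorescence, with a stated time of 90 min, tested at 1 uM; on this read-out lower numbers stand for less inhibition and higher numbers for more inhibition at the one concentration tested (going by the name of the read-out):

- compound 1 `COc1ccc(C(=O)NO)cc1NC(=O)c1nc2ccccc2[nH]1` gives 63%
- compound 2 `COc1ccc(C(C)=O)cc1NC(=O)c1cc(C(=O)NO)ccc1OC` gives 71%

Within the data shown here, compound 2 has one of only two numbers known here, and the number of compound 1 lies within the usual scatter of it, so the two measured compounds cannot be told apart on this read-out. Among the measured compounds shown here, neither measured pair differs in just one place, so no single-point step is available to lean on.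

Compound 3 `CCOc1ccc(C(C)=O)cc1NC(=O)c1cc(C(=O)NO)ccc1OC` has not yet been measured. It differs from compound 2 in one place: methyl in place of hydrogen on a saturated chain carbon bound to an oxygen on an aromatic ring. The change adds one small group on a chain that already hangs off the aromatic ring, and nothing else in the molecule moves.

For the measured compounds named here, with no measured step of this kind to compare against, the expectation rests on the small size of the change alone: the step from compound 2 to compound 3 in this assay is expected to be no larger than the scatter, with no clear direction, as a number 3 percentage points lower from compound 2 to compound 3 (within the scatter). Compound 3 is therefore estimated to give 68% in this assay, with a range from 50% to 85%.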

Compound 3, a percentage reported as inhibition, at one concentration (the size of the read-out at that concentration, not a potency): 61%
The estimate for compound 3 lay 7 percentage points above the measured number, within the range that was stated.
By their numbers in this assay, from the lowest: compounds 3, 1 and 2 (each within the scatter of the next).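

Among these compounds, the swap of methoxy for ethoxy is the first change in one place that can be read in this assay, and it comes out as a number 10 percentage points lower from compound 2 to compound 3 (within the scatter) on this read-out. Among the compounds shown here, until now, the only comparison was between compounds that differ in several places, so nothing could be said about this position on its own; now there is a first sign that one added methyl on this chain leaves compound 3 indistinguishable from compound 2 at the single concentration tested. Nothing available here explains the size of this step or links it to any property of the ethoxy group.

Still open, from the compounds shown here alone, is whether a longer chain such as propoxy, or a different group such as an amine or a carboxylic acid, at this position would produce a step beyond the usual scatter. A single step also cannot show whether the same swap of methoxy for ethoxy would read alike on a different core, such as that of compound 1.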